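The compounds below may be only part of what the source reports. "The series", "measured", "known", "first", "only" and "open" are said of these compounds alone.

In a functional assay on HepG2 cells (Homo sapiens) for cytotoxicity, read by MTT assay, with a stated time of 48 h (a higher number here means a weaker inhibitor, a lower number a stronger inhibitor), compound 2 `CNC(=O)CSc1nc2ccc(NC(=O)c3ccc([N+](=O)[O-])cc3)cc2s1` reaches only a limit of the assay, > 100000 nM, not a number. Compound 1 `CNC(=O)CSc1nc2ccc(NC(=O)c3ccccc3OC)cc2s1` differs from compound 2 by 2-methoxyphenyl in place of 4-nitrophenyl on a carbonyl carbon. In this assay compound 1 gives 18500 nM. That change made an at least 5.4-fold lower number from compound 2 to compound 1 (0.73 log units; beyond the scatter). Compound 3 `O=C(CSc1nc2ccc(NC(=O)c3ccc([N+](=O)[O-])cc3)cc2s1)NCc1ccccc1` differs from compound 2 by phenyl in place of hydrogen on a saturated chain carbon bound to an amide-type nitrogen. For compound 3 this assay again reports only a limit, > 100000 nM, not a number. Hence a step that the two limits leave unreadable from compound 2 to compound 3, both values sitting at the limit of > 100000 nM in this assay, at which 2 of the 3 values shown sit. Compound 4 `COc1ccccc1C(=O)Nc1ccc2nc(SCC(=O)NCc3ccccc3)sc2c1` has not yet been measured; it differs from compound 3 by 2-methoxyphenyl in place of 4-nitrophenyl on a carbonyl carbon, the same change as from compound 2 to compound 1, at the same place. Compound 4 is expected to show an at least 4.0-fold lower number from compound 3 to compound 4 (0.60 log units; beyond the scatter) because the same change gave an at least 5.4-fold lower number from compound 2 to compound 1 (0.73 log units; beyond the scatter). Compound 4 is therefore estimated at 25000 nM.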

Compound 4, half-maximal inhibitory concentration: 8000 nM
Beside the measured number, compound 4's estimate is 3.1-fold (0.49 log units) above it; the range from low to high includes it.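

In this assay, 2-methoxyphenyl in place of 4-nitrophenyl on the carbonyl carbon gives an at least 12-fold lower number from compound 3 to compound 4 (1.09 log units; beyond the scatter), so the number falls with this change on both cores shown. This does not show that the change has the same size on each core: the same change on two cores in this assay, an at least 5.4-fold lower number (0.73 log units; beyond the scatter) from compound 2 to compound 1 and an at least 12-fold lower number (1.09 log units; beyond the scatter) from compound 3 to compound 4; the limit leaves it open whether they differ. With the 2-methoxyphenyl group in place, phenyl in place of hydrogen on the chain carbon gives a 2.3-fold lower number from compound 1 to compound 4 (0.36 log units; beyond the scatter), whereas the same change between compound 2 and compound 3 cannot be read, as both are limits of the assay and not numbers: the limit of > 100000 nM in this assay, at which 2 of the 4 values shown sit.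

Two cores cannot show whether the change would carry to a third. Going by these compounds alone, also open is how an amine or a carboxylic acid on the phenyl ring would compare with 2-methoxyphenyl, or a longer chain with the one in compound 4.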